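Adding trifluoromethyl to compound 2

The source may hold more compounds than are shown below. What is called first, only, known or untested is meant among the compounds shown, and "the series" means these compounds.

- compound 1 `Nc1nc(-c2nn(Cc3ccccc3F)c3ncccc23)nc(N)c1NC(=O)OCC(F)(F)F` gives 35 mL/min/kg in an ADME assay on cells (Hepatocyte, Rattus norvegicus) for pharmacokinetics, read by LC-MS, with a stated time of 90 min, tested at 1 uM; a higher number here means faster removal of the compound, a lower number slower removal
- compound 2 `Nc1nc(-c2nn(Cc3ccccc3F)c3ncccc23)nc(N)c1N1CCOC1=O` gives 6.67 mL/min/kg in this assay

Compound 2, at 6.67 mL/min/kg, is the lower of the two measured compounds. Compound 3 `Nc1nc(-c2nn(Cc3ccccc3F)c3ncccc23)nc(N)c1N1C[C@@H](C(F)(F)F)OC1=O` differs from it by trifluoromethyl in place of hydrogen on a saturated ring carbon, with trifluoromethyl in place of hydrogen on a saturated ring carbon. Among the measured compounds shown here, the only measured step, a 5.2-fold lower number from compound 1 to compound 2 (0.72 log units; beyond the scatter), lies beyond the scatter but involves a different change, and no measurement covers this ring carbon. Only a slight rise in this assay is therefore expected, within the scatter: a 1.3-fold higher number from compound 2 to compound 3 (0.13 log units; within the scatter). The estimate for compound 3 is 9 mL/min/kg, with an expected range of 4 mL/min/kg to 20 mL/min/kg.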

Compound 3, clearance: 26.7 mL/min/kg
Compound 3: the middle estimate sits 3.0-fold (0.47 log units) below what was measured, outside the stated range (above it).
By their numbers in this assay, from the lowest: compound 2; then compounds 3 and 1 (each within the scatter of the next).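

In this assay, trifluoromethyl in place of hydrogen on the saturated ring carbon next to the ring oxygen is not a neutral change, giving a 4.0-fold higher number from compound 2 to compound 3 (0.60 log units; beyond the scatter) and showing that this carbon affects the read-out. The 2-oxo-1,3-oxazolidin-3-yl ring therefore does not hold the low number whatever it carries: with 2-oxo-5-(trifluoromethyl)-1,3-oxazolidin-3-yl in place of ((2,2,2-trifluoroethoxy)carbonyl)amino there is only a 1.3-fold lower number from compound 1 to compound 3 (0.12 log units; within the scatter) and no separation. Nothing measured here bears on the cause of the rise. Still open, from the compounds shown here alone, is whether the rise is specific to trifluoromethyl or also comes with a smaller group such as methyl or hydroxyl on this carbon. The opposite configuration at this carbon also remains to be compared.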